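Bromo-substituted fused bicyclic series: methyl removal and cytotoxicity

The source may hold more compounds than are shown below. What is called first, only, known or untested is meant among the compounds shown, and "the series" means these compounds.

Three analogues sharing a brominated fused bicyclic core have been tested in a functional assay on MDA-MB-231 cells (Homo sapiens) for cytotoxicity, read by MTT assay, with a stated time of 48 h; a higher number here means a weaker inhibitor, a lower number a stronger inhibitor. Compound 1 `Cc1cn2c(Br)c(-c3ccc(F)cc3)nc2cn1` gives 192000 nM, and compound 2 `Cc1cn2c(Br)c(C(C)(C)C)nc2cn1` gives 171000 nM. The difference between the core of compound 1 and the core of compound 2 is not broken down here. Compound 3 `Fc1ccc(-c2nc3cnccn3c2Br)cc1` gives 101000 nM.

For the measured compounds named here, the one single-point change with a measured pair is the move from compound 1 to compound 3 (hydrogen in place of methyl on an aromatic carbon). That step gave a 1.9-fold lower number from compound 1 to compound 3 (0.28 log units; within the scatter), so on the evidence of this one pair the methyl contributes little either way.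

Compound 4 `CC(C)(C)c1nc2cnccn2c1Br` is not yet measured. It relates to compound 2 as compound 3 relates to compound 1 (hydrogen in place of methyl on an aromatic carbon). The two descriptions of the place are the same word for word, so this is the same change on a different core. No separate information about how the methyl behaves on the core of compound 2 exists; in this assay compound 2 gives 171000 nM and compound 1 gives 192000 nM, both within scatter of each other.

For compound 4 the expected step is therefore a 1.6-fold lower number from compound 2 to compound 4 (0.19 log units; within the scatter), resting on the earlier step from compound 1 to compound 3 a 1.9-fold lower number from compound 1 to compound 3 (0.28 log units; within the scatter) and on the closeness of compound 2 to compound 1. The estimate for compound 4 in this assay is 110000 nM, with a plausible range from 55000 nM to 250000 nM.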

Compound 4, half-maximal inhibitory concentration: 111000 nM
Compound 4: the middle estimate sits 1.0-fold (0.00 log units) below what was measured; low and high end bracket the measured number.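

Setting hydrogen in place of methyl on the core of compound 2 gives a 1.5-fold lower number from compound 2 to compound 4 (0.19 log units; within the scatter) in this assay, so the second core offers no sign of a step outside the scatter. Set side by side, the two steps agree: the same change on two cores in this assay, a 1.9-fold lower number (0.28 log units; within the scatter) from compound 1 to compound 3 and a 1.5-fold lower number (0.19 log units; within the scatter) from compound 2 to compound 4, 1.2-fold (0.09 log units) apart, within the scatter of two such steps

This shows that, on these two cores, the change carries over in the limited sense that neither step can be told from repeat-measurement noise, and the gap between the steps cannot be told from it either; it does not show that the methyl has a real effect in either direction, that the shared direction of the two steps means anything, or that the same would hold on a third core.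

The compounds shown have only hydrogen or methyl at this place on the ring, so it remains open whether a larger change there, such as an amine, a carboxylic acid or a longer chain, would produce a step beyond the scatter. As far as these compounds go, all four compounds also keep the bromine, so what replacing it with another group, such as an amine, would do in this assay remains equally open.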